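A few compounds are considered here, and "the series" means these few. Any claim that something is new, unique, unknown or untested is made for them only; others in the source may bear on it.

In a functional assay on MCF cells (Homo sapiens) for antiproliferative activity, with a stated time of 72 h (a lower number here means a stronger inhibitor, a higher number a weaker inhibitor), compound 1 `OC[C@H]1O[C@@H](n2cnc3c(NCc4cccc(F)c4)ncnc32)[C@H](O)[C@@H]1O` gives 15300 nM. For compound 2 `COc1cc(CNc2ncnc3c2ncn3[C@@H]2O[C@H](CO)[C@@H](O)[C@H]2O)cc(OC)c1` the assay reports only a limit, > 166000 nM. Among the measured compounds shown here, the one measured step is an at least 10-fold higher number from compound 1 to compound 2 (1.03 log units; beyond the scatter), which is large and beyond the scatter, and it came with 3,5-dimethoxyphenyl in place of 3-fluorophenyl on a saturated chain carbon bound to a nitrogen on an aromatic ring. Compound 3 `OC[C@H]1O[C@@H](n2cnc3c(NCc4ccc(F)c(F)c4F)ncnc32)[C@H](O)[C@@H]1O` differs from compound 2 at that same place: 2,3,4-trifluorophenyl in place of 3,5-dimethoxyphenyl on a saturated chain carbon bound to a nitrogen on an aromatic ring. The 3,5-dimethoxyphenyl leaves again, and a fluorine-bearing phenyl returns, as in compound 1 at 15300 nM. For the measured compounds named here, that single step is the only guide, so a large move to a lower number in this assay is expected, roughly undoing it. The expected step is an at least 7.5-fold lower number from compound 2 to compound 3 (0.87 log units; beyond the scatter). For compound 3 the estimated value is 22000 nM, with an expected range of 7000 nM to 70000 nM.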

Compound 3, half-maximal inhibitory concentration: > 166000 nM
Compound 3 ended at the assay's limit; the forecaster's own chance of this, stated with the estimate: 15%; at least 7.5-fold (0.87 log units) between middle value and limit.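

In this assay compound 3 gives only a limit, > 166000 nM, so a fluorine-bearing phenyl at this place does not by itself preserve the measurable value of compound 1. With 2,3,4-trifluorophenyl in place of 3-fluorophenyl, the result is an at least 10-fold higher number from compound 1 to compound 3 (1.03 log units; beyond the scatter), so among the compounds shown a large move at this place is no longer tied to 3,5-dimethoxyphenyl alone. The step from compound 2 to compound 3 cannot be read, and both compounds stop at the same point: the limit of > 166000 nM in this assay, at which 2 of the 3 values shown sit.

From the compounds shown here alone, only compound 1 has a measured number, so how far compound 2 and compound 3 actually differ stays open. Also open, going by these compounds, is how an amine, a carboxylic acid or a longer chain at this place would read in this assay.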